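Following a Sulfur Substituent Swap in Growth Inhibition

This account rests on a few compounds, and the source may have more. Where it says the series, first, only, none or still open, it means among the compounds named here.

Measured in a functional assay on A-375 cells (Homo sapiens) for inhibition, read by CCK-8 assay, with a stated time of 72 h, tested at 8 uM; a lower number here means less inhibition of growth, a higher number more inhibition of growth at the concentration tested:
- Compound 1 `Nc1ccccc1NC(=O)/C=C/c1ccc(CSc2cccc(F)c2)cc1`: 9.08%
- Compound 2 `Nc1ccccc1NC(=O)c1ccc(CSc2nccc(C(F)(F)F)n2)cc1`: 80.1%

Compound 1, at 9.08%, is the lower of the two measured compounds, and compound 2, at 80.1%, lies beyond the scatter above it. Compound 3 `CC(C)(C)c1ccc(SCc2ccc(/C=C/C(=O)Nc3ccccc3N)cc2)cc1` has not yet been measured. It keeps the core of compound 1 but carries 4-(tert-butyl)phenyl in place of 3-fluorophenyl on a sulfur. Among the measured compounds shown here, no measured pair shows a step of this kind, so the expectation rests on compound 1 at 9.08% alone. In this assay, a small upward step, not clearly beyond the scatter, is expected, and the estimated change is a number 8.9 percentage points higher from compound 1 to compound 3 (within the scatter). Compound 3 is estimated at 18%, with an expected range of 5% to 45%.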

Compound 3, percent growth inhibition at one concentration: 35.5%
Compound 3: middle estimate off by 17.5 percentage points, on the low side; the measured number falls inside the stated range.
By their numbers in this assay, from the lowest: compound 1; then compound 3; then compound 2.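

With the core of compound 1 held fixed, the group on the sulfur whose other neighbour is a saturated chain carbon proves able to move the read-out: 4-(tert-butyl)phenyl in place of 3-fluorophenyl gives a number 26.4 percentage points higher from compound 1 to compound 3 (beyond the scatter) in this assay as the test of growth inhibition. The two groups share a six-membered aromatic ring of carbon only and count no hydrogen-bond donors or acceptors. The entering group has 10 heavy atoms against 7 for the group that leaves, and it carries no fluorine. Nothing available accounts for the size or direction of this step.

A single pair cannot separate the arrival of the tert-butyl group from the departure of the fluorine. From the compounds shown here alone, how a plain phenyl, or a ring bearing an amine or a carboxylic acid, would behave on the same sulfur remains open.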